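Changing the aryl group on a shared core

The compounds below may be only part of what the source reports. "The series", "measured", "known", "first", "only" and "open" are said of these compounds alone.

Measured so far in a functional assay on CCRF-CEM cells (Homo sapiens) for antiproliferative activity; on this read-out higher numbers stand for weaker inhibition and lower numbers for stronger inhibition
- compound 1 `COc1cc(C(=O)c2sc(-c3ccc(Br)cc3)cc2N)cc(OC)c1OC` gives 86 nM
- compound 2 `COc1cc(C(=O)c2sc(-c3ccc(I)cc3)cc2N)cc(OC)c1OC` gives 150 nM
- compound 3 `COc1cc(C(=O)c2sc(-c3ccncc3)cc2N)cc(OC)c1OC` gives 110 nM

Compound 3 has no clear rank among these, since its value lies within the scatter of both others. Compound 4 `COc1cc(C(=O)c2sc(-c3ccccc3Cl)cc2N)cc(OC)c1OC` is not yet measured and differs from compound 3 by 2-chlorophenyl in place of pyridin-4-yl on an aromatic carbon with 2-chlorophenyl in place of pyridin-4-yl on an aromatic carbon. Two measured steps at this place bear on it, a 1.3-fold higher number from compound 1 to compound 3 (0.11 log units; within the scatter) and a 1.4-fold lower number from compound 2 to compound 3 (0.13 log units; within the scatter) and both stayed within the scatter, as did a 1.7-fold higher number from compound 1 to compound 2 (0.24 log units; within the scatter) in the same group. Among the measured compounds shown here, no measured compound carries 2-chlorophenyl, so the range stays wide. The expected step is a 1.4-fold higher number from compound 3 to compound 4 (0.13 log units; within the scatter) and none beyond the scatter is expected in this assay for this change. For compound 4 the estimate is 150 nM with 50 nM to 600 nM as the expected range.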

Compound 4, half-maximal inhibitory concentration: 16 nM
Estimate against measurement, compound 4: 9.4-fold (0.97 log units) above; the whole stated range lies above it.
By their numbers in this assay, from the lowest: compound 4; then compounds 1, 3 and 2 (each within the scatter of the next).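

In this assay, the aryl group on this carbon of the shared core proves able to shift the read-out beyond the scatter, with a 6.9-fold lower number from compound 3 to compound 4 (0.84 log units; beyond the scatter), a 5.4-fold lower number from compound 1 to compound 4 (0.73 log units; beyond the scatter) and a 9.4-fold lower number from compound 2 to compound 4 (0.97 log units; beyond the scatter), whereas the three earlier groups stayed within the scatter of one another. Compound 4 differs from each of them by the whole aryl group, so the step cannot be assigned to the chlorine alone or to where it sits on the ring. No evidence shown here accounts for the lower number. Going by these compounds, what remains open is how an unsubstituted phenyl would compare, and whether a bromine or a methyl group in place of the chlorine of 2-chlorophenyl would keep the number as low.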